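Amide-aryl variation on a shared fused core

This account rests on a few compounds, and the source may have more. Where it says the series, first, only, none or still open, it means among the compounds named here.

Measured compounds:
compound 1 `COc1cc2c(Oc3ccc(NC(=O)c4cc(-c5ccccc5F)ccn4)cc3F)ccnc2cc1OCCCN1CCCCC1` — in a functional assay on A549 cells (Homo sapiens) for cytotoxicity, read by MTT assay, with a stated time of 72 h (a higher number here means a weaker inhibitor, a lower number a stronger inhibitor), compound 1 gives "not determined" (no result reported)
compound 2 `COc1cc2c(Oc3ccc(NC(=O)c4cc(-c5ccc(C(F)(F)F)cc5)ccn4)cc3F)ccnc2cc1OCCCN1CCCCC1` — in this assay compound 2 gives 1640 nM
compound 3 `COc1ccc(-c2ccnc(C(=O)Nc3ccc(Oc4ccnc5cc(OCCCN6CCCCC6)c(OC)cc45)c(F)c3)c2)cc1` — in this assay compound 3 gives "not determined" (no result reported)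

Compound 3 stands without a number; compound 1 likewise carries no single value, so the only figure in the series is that of compound 2. Compound 4 `COc1cc2c(Oc3ccc(NC(=O)c4cc(-c5ccccc5)ccn4)cc3F)ccnc2cc1OCCCN1CCCCC1` follows from compound 3 by hydrogen in place of methoxy on an aromatic carbon. For the measured compounds named here, no measured pair differs in one place, so no step size is known from the data; the change is small and is expected to move the read-out, if at all, no further than the scatter. On compound 2 as the sole anchor, compound 4 is estimated at 1500 nM, with a range from 400 nM to 6000 nM.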

Compound 4, half-maximal inhibitory concentration: 1800 nM
For compound 4 the middle estimate is 1.2-fold (0.08 log units) below the measured one; measured number inside the range.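

Hydrogen in place of trifluoromethyl on this aromatic carbon, para to a large group, gives a 1.1-fold higher number from compound 2 to compound 4 (0.04 log units; within the scatter) in this assay, so this is the first step that can be read at this position. The 4-methoxyphenyl to phenyl change cannot be read, since compound 3 has no single number. No outside measurement bears on this result.

As far as these compounds go, whether an amine or a carboxylic acid on this carbon would give a value outside the scatter of compound 4 remains open. So does the effect of a longer chain there.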